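Replacing 4-cyanophenyl with 2,6-difluorophenyl: an unmeasured step

The compounds below may be only part of what the source reports. "The series", "measured", "known", "first", "only" and "open" are said of these compounds alone.

Of the compounds shown here, two have been measured so far. In a physicochemical assay for lipophilicity (on this read-out lower numbers stand for lower lipophilicity and higher numbers for higher lipophilicity), compound 1 (`C[C@H]1CC[C@@H]2[C@@H](OC(=O)[C@]23CC(c2ccc(N(C)C)cc2)=NO3)[C@]2(C)C(=O)C=C[C@@]12O`) gives 1.51 while compound 2 (`C[C@H]1CC[C@@H]2[C@@H](OC(=O)[C@]23CC(c2ccc(C#N)cc2)N(c2ccccc2)O3)[C@]2(C)C(=O)C=C[C@@]12O`) gives 2.94 and so stands highest of the two, beyond the usual scatter.

Compound 3 (`C[C@H]1CC[C@@H]2[C@@H](OC(=O)[C@]23CC(c2c(F)cccc2F)N(c2ccccc2)O3)[C@]2(C)C(=O)C=C[C@@]12O`) has not been measured yet. It differs from compound 2 in one place, with 2,6-difluorophenyl in place of 4-cyanophenyl on a saturated ring carbon. Within the data shown here, no measured pair differs in just one place, so the data offer no direct precedent, and the expectation rests on the structural change alone.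

The expected change in this assay is a modest rise, slightly beyond the scatter, estimated as a number 0.46 log units higher from compound 2 to compound 3 (beyond the scatter) for this single swap. For compound 3 the estimated value is 3.4 with an expected range from 2.9 to 3.9 on this scale.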

Compound 3, partition coefficient: 3.42
Compound 3: middle estimate off by 0.02 log units, on the low side; the range from low to high includes it.
By their numbers in this assay, from the lowest: compound 1; then compound 2; then compound 3.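

Among these compounds, this is the first pair of compounds that differ in one place, so the group on this saturated ring carbon can now be read on its own in this assay. Replacing 4-cyanophenyl with 2,6-difluorophenyl gives a number 0.48 log units higher from compound 2 to compound 3 (beyond the scatter), which shows that the read-out responds to a change at this carbon even though both groups carry one six-membered aromatic ring of carbon only and the same number of heavy atoms. Nothing available explains this rise.

From the compounds shown here alone, it remains open whether the step comes from losing the nitrile, from gaining the two fluorines, or from both, and a plain phenyl group on this carbon would help separate them. Going by these compounds, how a carboxylic acid or a hydroxyl group at this place would read also remains open.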